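The source may report more compounds than this note shows. Statements on the series, on what has been measured and on what is new or still open speak of the compounds shown alone.

Measured so far:
- compound 1 `CN(C)C1CCN(Cc2ccc(NC(=O)c3ccc(OCCCCl)c([N+](=O)[O-])c3)cc2C(F)(F)F)C1`: 5800 nM
- compound 2 `CCC(=O)Nc1cc(C(=O)Nn2c(C)nnc2S)ccc1OC`: > 200000 nM, a limit

Going by the values given here, in a toxicity assay on Huh-7.5 cells (Homo sapiens) for inhibition, read by MTT assay, with a stated time of 96 h (on this read-out lower numbers stand for higher toxicity in this test and higher numbers for lower toxicity in this test), compound 1 gives 5800 nM, the only true number so far. Compound 2 gives > 200000 nM, and this value is a limit. The two compounds therefore cannot be placed on a common numerical scale, and compound 1 has no measured neighbour.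

Compound 3 `CN1CCN(Cc2ccc(NC(=O)c3ccc(OCCCCl)c([N+](=O)[O-])c3)cc2C(F)(F)F)CC1` keeps the core of compound 1 and changes one group: 4-methylpiperazin-1-yl in place of 3-(dimethylamino)pyrrolidin-1-yl on a saturated chain carbon bound to an aromatic carbon. In words, 4-methylpiperazin-1-yl stands in place of 3-(dimethylamino)pyrrolidin-1-yl on a saturated chain carbon bound to an aromatic carbon.

Among the compounds with values here, no step between measured compounds shows what an exchange of this kind does in this assay. The expectation is therefore no change beyond the usual scatter, with no direction favoured. The expected change is a 1.1-fold higher number from compound 1 to compound 3 (0.05 log units; within the scatter). This expectation is anchored only on compound 1 at 5800 nM, and the range is kept wide for that reason. Compound 3 is estimated at 6500 nM, with an expected range of 2500 nM to 18000 nM.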

Compound 3, half-maximal cytotoxic concentration: 6800 nM
For compound 3 the middle estimate is 1.0-fold (0.02 log units) below the measured one; the measured number falls inside the stated range.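

In this assay, going by these compounds alone, the exchange of 3-(dimethylamino)pyrrolidin-1-yl for 4-methylpiperazin-1-yl on a saturated chain carbon bound to an aromatic carbon gives a 1.2-fold higher number from compound 1 to compound 3 (0.07 log units; within the scatter) and is the only readable step. On this evidence, the place tolerates a six-membered non-aromatic ring with 2 hetero atoms as well as a five-membered non-aromatic ring with 1 hetero atom, with no reading beyond the scatter in this test, and the count of 7 heavy atoms against 8 makes no visible difference here. Nothing measured among the compounds shown speaks to a cause for this step.

Going by these compounds, both groups compared at this place hold two ring or chain nitrogens and no charge, so the effect of morpholin-4-yl, a carboxylic acid or a longer chain there remains open. On these data alone, the step also covers this one place only, and what a change elsewhere on the shared core, a nitrile for instance, does to the reading stays unknown.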